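A Second Bromine on an Inactive Core

A few compounds are considered here, and "the series" means these few. Any claim that something is new, unique, unknown or untested is made for them only; others in the source may bear on it.

Compound 1 `COCc1nc(Br)c2cnnc(O)n12` shows no measurable inhibition in a functional assay for inhibition, with Homo sapiens as the target; a higher number here means a weaker inhibitor, a lower number a stronger inhibitor. In this assay compound 1 gives > 48000 nM, which is a limit of the assay and not a number. Compound 2 `CCCc1nc(Br)c2cnnc(O)n12` gives > 48000 nM, again only a limit. Compound 3 `COCc1ncc2cnnc(O)n12` gives > 48000 nM, also a limit. The steps a step that the two limits leave unreadable from compound 1 to compound 2 and a step that the two limits leave unreadable from compound 1 to compound 3 therefore cannot be sized, because of the limit of > 48000 nM in this assay, at which 3 of the 3 values shown sit. Compound 4 `COCc1nc(Br)c2c(Br)nnc(O)n12` differs from compound 1 by bromo in place of hydrogen on an aromatic carbon. Going by the values given here, neither measured step touches this carbon, and none of the measured compounds reaches a number. Compound 4 is therefore expected to sit at the same limit, an estimate of 60000 nM with a range from 30000 nM to 200000 nM. The expected step that the limit leaves unreadable from compound 1 to compound 4 is accordingly none beyond the scatter.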

Compound 4, half-maximal inhibitory concentration: > 48000 nM
Compound 4: only a limit was reported; the forecaster's own chance of this, stated with the estimate: 85%; the middle value is on the limit's open side.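

The step from compound 1 to compound 4 cannot be read, since both compounds give only a limit of the assay: the limit of > 48000 nM in this assay, at which 4 of the 4 values shown sit.

The compounds shown leave open whether any change to the shared core gives measurable inhibition.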